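Three Limits on the Aromatic Nitrogen, and a Fourth Compound

The source may hold more compounds than are shown below. What is called first, only, known or untested is meant among the compounds shown, and "the series" means these compounds.

Compound 1, `Cc1cccc(-n2nncc2CN2C(=O)C3(C(C#N)=C(N)Oc4c3c3nc5ccccc5nc3c3ccccc43)c3ccccc32)c1`, gives in an ADME assay on L02 cells (Homo sapiens) for antiproliferative activity, read by MTT assay, with a stated time of 48 h (on this read-out higher numbers stand for weaker inhibition and lower numbers for stronger inhibition), a value of > 50000 nM, which is a limit of the assay.
Compound 2, `N#CC1=C(N)Oc2c(c3nc4ccccc4nc3c3ccccc23)C12C(=O)N(Cc1cnnn1-c1cccc(Br)c1)c1ccccc12`, gives in this assay a value of > 50000 nM, again a limit of the assay.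
Compound 3, `CCOc1ccccc1-n1nncc1CN1C(=O)C2(C(C#N)=C(N)Oc3c2c2nc4ccccc4nc2c2ccccc32)c2ccccc21`, gives in this assay a value of > 50000 nM, also a limit of the assay.

Compound 3 therefore stands nowhere on a scale of numbers: only a limit is known for it, and the two other values shown are limits as well, all three sitting at the limit of > 50000 nM in this assay, at which 3 of the 3 values shown sit. The three steps between the measured compounds, a step that the two limits leave unreadable from compound 1 to compound 2, a step that the two limits leave unreadable from compound 1 to compound 3 and a step that the two limits leave unreadable from compound 2 to compound 3, are for the same reason unreadable in size; whether the substituent on the aromatic nitrogen moves the read-out at all cannot be told from them.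

Compound 4, `Cc1cc(C)cc(-n2nncc2CN2C(=O)C3(C(C#N)=C(N)Oc4c3c3nc5ccccc5nc3c3ccccc43)c3ccccc32)c1`, differs from compound 3 by 3,5-dimethylphenyl in place of 2-ethoxyphenyl on an aromatic nitrogen: the 2-ethoxyphenyl leaves and a 3,5-dimethylphenyl enters on the aromatic nitrogen. Since every measured step at this position is unreadable, no direction or size of step is expected, and the step that the limit leaves unreadable from compound 3 to compound 4 is estimated as none that the assay could read. Compound 4 is accordingly expected to give about 60000 nM in this assay, somewhere between 20000 nM and 200000 nM, most likely reported once more as a limit.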

Compound 4, half-maximal inhibitory concentration: > 50000 nM
Compound 4 was reported as a limit; the forecaster's own chance of this, stated with the estimate: 85%; the middle value lies beyond the limit too.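

Compound 4 joins compound 1, compound 2 and compound 3 as a limit of this assay, so no new step can be read from compound 4 to any of them: the limit of > 50000 nM in this assay, at which 4 of the 4 values shown sit.

The compounds shown leave open whether changing the aryl group on the aromatic nitrogen moves the read-out at all, and how far past the limit each compound lies.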